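Solubility notes on the chain substituent at the core

The source may hold more compounds than are shown below. What is called first, only, known or untested is meant among the compounds shown, and "the series" means these compounds.

Three compounds of this series have been run in a physicochemical assay for solubility, at pH 7.4; a lower number here means a less soluble compound, a higher number a more soluble compound. Compound 1 `CCOCc1nc(Nc2ccc(C(F)(F)F)cc2)c2ccc(-c3ncccc3C(F)(F)F)cc2n1` gives 0.6 ug/mL and stands highest of the three numbers. Compound 2 `OCCc1nc(Nc2ccc(C(F)(F)F)cc2)c2ccc(-c3ncccc3C(F)(F)F)cc2n1` gives 0.02 ug/mL, and compound 3 `CS(=O)(=O)CCc1nc(Nc2ccc(C(F)(F)F)cc2)c2ccc(-c3ncccc3C(F)(F)F)cc2n1` gives 0.2 ug/mL. Both steps away from compound 1 lower the number: a 30-fold lower number from compound 1 to compound 2 (1.48 log units; beyond the scatter) and a 3.0-fold lower number from compound 1 to compound 3 (0.48 log units; beyond the scatter). Between the two lower compounds, a 10-fold higher number from compound 2 to compound 3 (1.00 log units; beyond the scatter).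

Compound 4 `FC(F)(F)c1ccc(Nc2nc(CN3CCCC3)nc3cc(-c4ncccc4C(F)(F)F)ccc23)cc1` has not been measured. It differs from compound 1 in one place: pyrrolidin-1-yl in place of ethoxy on a saturated chain carbon bound to an aromatic carbon. Among the compounds with values here, no measured step exchanges the ethoxy for a ring or introduces a nitrogen on that chain, so the three steps above speak only indirectly. What they show is that compound 1 is the upper point of the set and that the two replacements tried so far moved the number downward, by a modest and by a large step.

The change to pyrrolidin-1-yl is of a different kind from either, so the measured steps do not fix its direction. For compound 4 the number in this assay is estimated at 3 ug/mL, in a range from 0.4 ug/mL to 25 ug/mL, which would mean a step of a 5.0-fold higher number from compound 1 to compound 4 (0.70 log units; beyond the scatter) expected upward from compound 1, with wide uncertainty.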

Compound 4, solubility: 25 ug/mL
Compound 4: the middle estimate sits 8.3-fold (0.92 log units) below what was measured, and the stated range covers the measured number.
By their numbers in this assay, from the lowest: compound 2; then compound 3; then compound 1; then compound 4.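

The exchange of ethoxy for pyrrolidin-1-yl on a saturated chain carbon bound to an aromatic carbon gives, in this assay, a 42-fold higher number from compound 1 to compound 4 (1.62 log units; beyond the scatter), so compound 1 is not the upper end for this place, and the number here can rise as well as fall. Against the other two chain groups the same compound stands further off, with a 130-fold higher number from compound 3 to compound 4 (2.10 log units; beyond the scatter) and a 1300-fold higher number from compound 2 to compound 4 (3.10 log units; beyond the scatter), which makes compound 4 the highest of the four and widens the spread reachable through this one place on the shared core. Nothing among the data shown offers a measured explanation for this rise.

The compounds shown do not separate the contribution of the nitrogen from that of the five-membered ring, as the change brings in both together. Dimethylamino, an open-chain amine, would test the nitrogen without the ring, while cyclopentyl would test the ring without the nitrogen, and morpholin-4-yl or piperidin-1-yl at the same place would show whether the high number in this assay extends beyond pyrrolidin-1-yl.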